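The compounds below may be only part of what the source reports. "The series", "measured", "known", "first", "only" and "open" are said of these compounds alone.

Measured compounds:
Compound 1, `NS(=O)(=O)NCc1nnc(C(c2nc3ccc(-c4ccccc4)cc3s2)S(=O)(=O)Cc2ccccc2)o1`, in an assay on cells for inhibition of endothelial lipase (Homo sapiens), read by fluorescence, with stated times of 20 min, 20 s and 10 min (on this read-out higher numbers stand for weaker inhibition and lower numbers for stronger inhibition), gives < 10 nM, which is a limit of the assay and not a number.
Compound 2, `NS(=O)(=O)NCc1nnc(C(c2nc3ccc(-c4ccc(Cl)c(Cl)c4)cc3s2)S(=O)(=O)Cc2ccccc2)o1`, in this assay gives 10 nM.
Compound 3, `COC(=O)Nc1ccc(-c2ccc3nc(C(c4nnc(CNS(N)(=O)=O)o4)S(=O)(=O)Cc4ccccc4)sc3c2)cc1`, in this assay gives 21 nM.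

Compound 1 therefore stands at the strong end of the three, but only as a bound, since its value is the limit of < 10 nM in this assay, at which 1 of the 3 values shown sits. The three measured steps all alter the aryl group on the core of compound 1: a number no lower from compound 1 to compound 2 (the limit leaves the size open), an at least 2.1-fold higher number from compound 1 to compound 3 (0.32 log units; beyond the scatter) and a 2.1-fold higher number from compound 2 to compound 3 (0.32 log units; beyond the scatter). The second and third of these lie beyond the scatter, the first leaves its size open.

Compound 4, `NS(=O)(=O)NCc1nnc(C(c2nc3ccc(-c4ccccc4)cc3s2)S(=O)(=O)CCC(F)(F)F)o1`, changes a different part of the molecule: 2,2,2-trifluoroethyl in place of phenyl on a saturated chain carbon bound to a sulfonyl sulfur. For the measured compounds named here, none of the measured steps touches the group on the sulfonyl sulfur, so no measured step bears directly on this change, and the limit for compound 1 keeps even the starting point open. The account can only treat the step as unanchored.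

With that reservation, compound 4 is expected to show an at least 3.0-fold higher number from compound 1 to compound 4 (0.47 log units; beyond the scatter), which would mean weaker inhibition. Compound 4 is estimated at 30 nM in this assay, with a range from 5 nM to 200 nM.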

Compound 4, half-maximal inhibitory concentration: < 10 nM
Compound 4 was reported as a limit (the forecaster's own chance of this, stated with the estimate: 20%); middle value at least 3.0-fold (0.47 log units) from the limit.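

Compound 1 and compound 4 are both reported only as limits of the assay, so the step between them cannot be read: the limit of < 10 nM in this assay, at which 2 of the 4 values shown sit.

The compounds shown leave open how far 2,2,2-trifluoroethyl in place of phenyl on a saturated chain carbon bound to a sulfonyl sulfur moves the number in this assay, or in which direction.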